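Three side-chain variants on a shared quinone core, a fourth estimated

This account rests on a few compounds, and the source may have more. Where it says the series, first, only, none or still open, it means among the compounds named here.

Three compounds sharing one core were tested in a functional assay on DU-145 cells (Homo sapiens) for cytotoxicity, read by MTT assay; a lower number here means a stronger inhibitor, a higher number a weaker inhibitor. Compound 1 `CC(=O)OCCO[C@H](CC=C(C)C)C1=CC(=O)c2c(O)ccc(O)c2C1=O` gives 15500 nM. Compound 2 `COC(C)CO[C@H](CC=C(C)C)C1=CC(=O)c2c(O)ccc(O)c2C1=O` gives 16600 nM. Compound 3 `CC[C@](C)(O)CC(=O)O[C@H](CC=C(C)C)C1=CC(=O)c2c(O)ccc(O)c2C1=O` gives 20500 nM. Every step among them stays within the scatter: a 1.1-fold higher number from compound 1 to compound 2 (0.03 log units; within the scatter), a 1.3-fold higher number from compound 1 to compound 3 (0.12 log units; within the scatter), and a 1.2-fold higher number from compound 2 to compound 3 (0.09 log units; within the scatter). Compound 2 therefore sits among numbers that cannot be told apart, its nearest neighbour being compound 1 and its furthest compound 3, both within the scatter.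

Compound 4 `CC(C)=CC[C@@H](OCCO)C1=CC(=O)c2c(O)ccc(O)c2C1=O` differs from compound 2 as follows: hydroxymethyl in place of 1-methoxyethyl on a saturated chain carbon bound to an oxygen on a saturated carbon. The step from compound 1 to compound 2 concerns the same place, a saturated chain carbon bound to an oxygen on a saturated carbon, and it produced a 1.1-fold higher number from compound 1 to compound 2 (0.03 log units; within the scatter); the two steps leading to compound 3, which exchange the whole group on the oxygen, were equally flat. For the measured compounds named here, the data thus give no example of a change at this place moving the number beyond the scatter, although a hydroxymethyl group in this position has not been tried. On that basis the step is expected to be a 1.0-fold higher number from compound 2 to compound 4 (0.01 log units; within the scatter), with no direction beyond the scatter. Compound 4 is estimated to give 17000 nM in this assay, within a range of 8000 nM to 36000 nM.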

Compound 4, half-maximal inhibitory concentration: 9900 nM
Estimate against measurement, compound 4: 1.7-fold (0.23 log units) above; the measured number falls inside the stated range.
By their numbers in this assay, from the lowest: compounds 4, 1, 2 and 3 (each within the scatter of the next, the first and the last beyond it).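

In this assay, this position now yields a step beyond the scatter, though a modest one: 2-hydroxyethyl in place of (2-hydroxy-2-methylbutyl)carbonyl on an oxygen on a saturated carbon (a 2.1-fold lower number from compound 3 to compound 4 (0.32 log units; beyond the scatter)). The two closer changes do not reach that size: hydroxymethyl in place of 1-methoxyethyl (a 1.7-fold lower number from compound 2 to compound 4 (0.22 log units; within the scatter)) and hydrogen in place of acetyl (a 1.6-fold lower number from compound 1 to compound 4 (0.19 log units; within the scatter)) both stay within the scatter, so compound 4 cannot be told apart from compound 1 or compound 2, and it separates only from compound 3. For the compounds shown here, no supporting measurement is available to explain the one step that passes the scatter.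

From the compounds shown here alone, it remains open whether an amine or a carboxylic acid at the end of this chain, or a longer chain ending in a hydroxyl, would move the number beyond the scatter from compound 2. Going by these compounds, it is also open whether a 2-methoxyethyl group, which would keep the chain of compound 4 but cap its terminal oxygen with methyl, would give a number closer to compound 4 or to compound 2.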